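The source may hold more compounds than are shown below. What is called first, only, known or untested is meant among the compounds shown, and "the series" means these compounds.

Working notes on the series in an ADME assay on MCF-10A cells (Homo sapiens) for cytotoxicity, read by MTT assay, with a stated time of 72 h; a higher number here means a weaker inhibitor of growth, a lower number a stronger inhibitor of growth.

Of the compounds shown here, three have numbers so far. Compound 1 `CS/C(=N\C(=O)c1ccno1)NC(=O)c1ccno1` gives 16900 nM in this assay, which places it second highest of the three. Compound 2 `O=C(/N=C(/NC(=O)c1csc([N+](=O)[O-])c1)[Se]Cc1ccccc1)c1csc([N+](=O)[O-])c1` gives 24400 nM in this assay, and this value sits within the scatter of the value for compound 1, so no order between the two can be read. Within the data shown here, compound 3 `C[Se]/C(=N\C(=O)c1cc(-c2ccccc2)nc2ccccc12)NC(=O)c1cc(-c2ccccc2)nc2ccccc12` gives 710 nM in this assay, a much lower number than compound 1, but compound 3 differs from compound 1 in more than one place and no single step connects them.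

Compound 4 `C[Se]/C(=N\C(=O)c1ccno1)NC(=O)c1ccno1` has not been measured. It differs from compound 1 as follows: a group of 2 heavy atoms (1 carbon, 1 selenium; no ring) in place of a group of 2 heavy atoms (1 carbon, 1 sulfur; no ring), on a carbon with a double bond to nitrogen. Among the measured compounds shown here, no measured pair isolates this change on the shared core of compound 1. The same selenium-bearing group is present in compound 3, but with a different core, so the low number of compound 3 cannot be ascribed to that group on its own.

Expectation for compound 4: a step from compound 1 that stays within the scatter, or at most a small move downward. Compound 4 is estimated at 12000 nM in this assay, with a range from 5000 nM to 30000 nM. The expected step of a 1.4-fold lower number from compound 1 to compound 4 (0.15 log units; within the scatter) is taken as small and not clearly beyond the scatter.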

Compound 4, concentration for 50% growth inhibition: 2890 nM
For compound 4 the middle estimate is 4.2-fold (0.62 log units) above the measured one; the measured number lies below the stated range.
By their numbers in this assay, from the lowest: compound 3; then compound 4; then compounds 1 and 2 (each within the scatter of the next).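

In this assay, putting the group of 2 heavy atoms (1 carbon, 1 selenium; no ring) in place of methylsulfanyl, on a carbon with a double bond to nitrogen, gives a 5.8-fold lower number from compound 1 to compound 4 (0.77 log units; beyond the scatter). Among these compounds, this is the first step that isolates a single change, and it shows that at this place on the shared core the exchange of sulfur for selenium is enough on its own to move the number beyond the scatter, toward stronger inhibition of growth. Nothing measured on these compounds bears on why the number moves.

This single pair does not show whether the same exchange gives a step of similar size on other cores. As far as these compounds go, how an amine or a longer chain on selenium would read at this carbon also remains open.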